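Halogen change on the arylamino group of the shared core

The source may report more compounds than this note shows. Statements on the series, on what has been measured and on what is new or still open speak of the compounds shown alone.

Compound 1 `C=CC(=O)Nc1cccc(NC(=O)CSc2nc(Nc3cccc(C)c3)c3ccccc3n2)c1` gives 12100 nM in a functional assay on NCI-H1975 cells (Homo sapiens) for inhibition, read by MTT assay, with a stated time of 72 h; a lower number here means a stronger inhibitor, a higher number a weaker inhibitor. Compound 2 `C=CC(=O)Nc1cccc(NC(=O)CSc2nc(Nc3ccc(Cl)cc3)c3ccccc3n2)c1` gives 7580 nM in this assay, and compound 3 `C=CC(=O)Nc1cccc(NC(=O)CSc2nc(Nc3ccc(Br)cc3)c3ccccc3n2)c1` gives 6280 nM. Compound 3 carries the lowest of the three numbers, yet both of its neighbours lie within the scatter: a 1.9-fold lower number from compound 1 to compound 3 (0.28 log units; within the scatter) and a 1.2-fold lower number from compound 2 to compound 3 (0.08 log units; within the scatter). Compound 4 `C=CC(=O)Nc1cccc(NC(=O)CSc2nc(Nc3ccc(Cl)c(Cl)c3)c3ccccc3n2)c1` is the next entry and differs from compound 3 by 3,4-dichlorophenyl in place of 4-bromophenyl on a nitrogen on an aromatic ring. Every measured step bears on this same ring: a 1.6-fold lower number from compound 1 to compound 2 (0.20 log units; within the scatter), a 1.9-fold lower number from compound 1 to compound 3 (0.28 log units; within the scatter) and the halogen exchange a 1.2-fold lower number from compound 2 to compound 3 (0.08 log units; within the scatter). None of them moved the number beyond the scatter, so for compound 4 no step beyond the scatter is expected in this assay, a 1.0-fold lower number from compound 3 to compound 4 (0.02 log units; within the scatter). Compound 4 is therefore estimated at 6000 nM, with a range from 3000 nM to 12000 nM.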

Compound 4, half-maximal inhibitory concentration: 19100 nM
Beside the measured number, compound 4's estimate is 3.2-fold (0.50 log units) below it; measured number outside the range, above it.
By their numbers in this assay, from the lowest: compounds 3, 2, 1 and 4 (each within the scatter of the next, the first and the last beyond it).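

On the aryl group at this nitrogen, steps beyond the scatter now appear in this assay: adding chloro in place of hydrogen on an aromatic carbon gives the first (a 2.5-fold higher number from compound 2 to compound 4 (0.40 log units; beyond the scatter)), and 3,4-dichlorophenyl in place of 4-bromophenyl gives the second (a 3.0-fold higher number from compound 3 to compound 4 (0.48 log units; beyond the scatter)). Set against 3-methylphenyl, however, 3,4-dichlorophenyl stays within the scatter (a 1.6-fold higher number from compound 1 to compound 4 (0.20 log units; within the scatter)). No measurement available here accounts for the higher number. On these data alone, whether a second bromo would give the same step remains open. So does the effect of an amine or a carboxylic acid on this phenyl ring.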